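Methyl for fluoro on the stilbene-like arm of a benzamide series

The compounds below may be only part of what the source reports. "The series", "measured", "known", "first", "only" and "open" are said of these compounds alone.

Measured so far:
compound 1, `COc1ccc(C(N)=O)cc1/C=C/c1ccc(C)cc1`, 48000 nM
compound 2, `COc1ccc(C(N)=O)cc1/C=C/c1ccc(F)cc1`, 24000 nM
compound 3, `COc1ccc(C(N)=O)cc1/C=C/c1ccccc1F`, 26000 nM

Of the compounds shown here, three have been measured in an ADME assay on HCT-116 cells (Homo sapiens) for antiproliferative activity; on this read-out lower numbers stand for stronger inhibition and higher numbers for weaker inhibition. Compound 1 has the structure `COc1ccc(C(N)=O)cc1/C=C/c1ccc(C)cc1` and in this assay compound 1 gives 48000 nM. Compound 2, `COc1ccc(C(N)=O)cc1/C=C/c1ccc(F)cc1`, gives 24000 nM in this assay. Compound 3, `COc1ccc(C(N)=O)cc1/C=C/c1ccccc1F`, gives 26000 nM in this assay. The difference between the cores of compound 3 and compound 2 is not broken down here.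

Within the measured set one change is seen once: from compound 2 to compound 1 the change is methyl in place of fluoro on an aromatic carbon, and it produced a 2.0-fold higher number from compound 2 to compound 1 (0.30 log units; within the scatter). The unmeasured compound 4, `COc1ccc(C(N)=O)cc1/C=C/c1ccccc1C`, arises from compound 3 by methyl in place of fluoro on an aromatic carbon. Going by the values given here, this is the same kind of change as the one from compound 2 to compound 1, but the place differs: in the earlier pair the group sits para to a large group, here it sits ortho to a large group.

Among the compounds with values here, compound 4 is therefore expected to show a step of about a 1.7-fold higher number from compound 3 to compound 4 (0.24 log units; within the scatter) in this assay, resting on the single earlier example, the step of a 2.0-fold higher number from compound 2 to compound 1 (0.30 log units; within the scatter), which itself lay within the scatter. Within the data shown here, with only one precedent, and that at a different place, the range is kept wide. The estimate for compound 4 in this assay is 45000 nM, between 20000 nM and 100000 nM.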

Compound 4, half-maximal inhibitory concentration: 11000 nM
Compound 4: the middle estimate sits 4.1-fold (0.61 log units) above what was measured; the measured number lies below the stated range.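

In this assay, methyl in place of fluoro on an aromatic carbon, ortho to a large group, gave a 2.4-fold lower number from compound 3 to compound 4 (0.37 log units; beyond the scatter), a modest step that nonetheless lies beyond the scatter. The change therefore cannot be carried from one core to the other in this series as a fixed increment, since the two steps differ, and the earlier one, being within the scatter, gave no firm direction to carry: the same change on two cores in this assay, a 2.0-fold higher number (0.30 log units; within the scatter) from compound 2 to compound 1 and a 2.4-fold lower number (0.37 log units; beyond the scatter) from compound 3 to compound 4, 4.7-fold (0.67 log units) apart, beyond the scatter of two such steps. This comparison rests on just two pairs, so it shows that the outcome of the swap depends on its setting, but it does not show whether the place of the group on the ring or some other difference between the cores accounts for the gap, nor that a methyl in this place would give a lower number on any other core.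

The compounds shown leave open whether other groups in the same place, such as chloro, methoxy or trifluoromethyl, would follow compound 4 or compound 3. They also leave open how the methyl swap would behave with a carboxylic acid or a nitrile in place of the primary amide on the shared core.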